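The compounds below may be only part of what the source reports. "The series", "measured", "known", "first", "only" and "open" are said of these compounds alone.

Measured so far in a functional assay on HepG2 cells (Homo sapiens) for inhibition, read by MTT assay, with a stated time of 48 h; a higher number here means a weaker inhibitor, a lower number a stronger inhibitor:
- compound 1, `COc1ccc(N(C)c2nc(C)nc3ccccc23)cc1C(=O)NCC[Se]C#N`: 179 nM
- compound 2, `C[Se]c1ccc(N(C)c2nc(C3CC3)nc3ccccc23)cc1`: 32 nM

Compound 1 stands at the highest number of the two. The nearest is compound 2, whose value in this assay is a lower number by a gap beyond the usual scatter, so compound 2 is the stronger of the pair as far as these two numbers show. Among the compounds with values here, no pair of measured compounds differs in one place only, so no single-change step size is known.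

Compound 3, `COc1ccc(N(C)c2nc(C)nc3ccccc23)cc1OCC[Se]C#N`, has not yet been measured in this assay. Relative to compound 1 the change is a group of 6 heavy atoms (3 carbon, 1 nitrogen, 1 oxygen, 1 selenium; no ring) in place of a group of 8 heavy atoms (4 carbon, 2 nitrogen, 1 oxygen, 1 selenium; no ring), on an aromatic carbon. The shared core, the methoxy group and the selenium-bearing chain end are kept; what shifts is the linking portion of the chain and its hydrogen-bond donor count.

Within the data shown here, with no measured step of this kind to lean on, the expected step from compound 1 to compound 3, a 1.1-fold lower number from compound 1 to compound 3 (0.05 log units; within the scatter), is taken as none beyond the scatter, in either direction. The estimate for compound 3 in this assay is 160 nM, with a range of 50 nM to 500 nM.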

Compound 3, half-maximal inhibitory concentration: 14 nM
For compound 3 the middle estimate is 11-fold (1.06 log units) above the measured one; measured number outside the range, below it.
By their numbers in this assay, from the lowest: compound 3; then compound 2; then compound 1.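

Within the data shown here, compound 1 to compound 3 is the first single-change step. In this assay it shows that this position, on an aromatic carbon ortho to a methoxy group, is far from indifferent to the linking portion of the chain: the step is large, with a 13-fold lower number from compound 1 to compound 3 (1.11 log units; beyond the scatter) on going to the group of 6 heavy atoms from the group of 8 heavy atoms. The selenium-bearing chain end, the methoxy group and the shared core are all kept, so the step belongs to the linking portion, where the carbonyl and the amide hydrogen leave and an ether oxygen takes their place, giving a group with 0 hydrogen-bond donors in place of one with 1 hydrogen-bond donor. Nothing at hand bears on what lies behind this step.

On these data alone, this one step changes the chain length, the carbonyl and the amide hydrogen together, so their separate shares stay open. A longer chain on the same ether oxygen, or a simple amine as the link, would begin to pull them apart.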